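Compound 3 to compound 4: fluoro to bromo

The compounds below may be only part of what the source reports. "The series", "measured", "known", "first", "only" and "open" are said of these compounds alone.

In an ADME assay on L02 cells (Homo sapiens) for cytotoxicity, read by MTT assay, with a stated time of 24 h (a higher number here means a weaker inhibitor, a lower number a stronger inhibitor), compound 1 `COc1ccc(/C=C2\CN(C)C/C(=C\c3ccccc3F)C2=O)cc1OC` gives 10500 nM, compound 2 `CN1C/C(=C\c2cccc([N+](=O)[O-])c2)C(=O)/C(=C/c2ccccc2F)C1` gives 13500 nM and compound 3 `CN1C/C(=C\c2ccc(F)cc2)C(=O)/C(=C/c2cccc([N+](=O)[O-])c2)C1` gives 17600 nM. These three values lie within the scatter of one another, so compound 3 is not separated from either neighbour on these numbers.

Compound 4 `CN1C/C(=C\c2ccc(Br)cc2)C(=O)/C(=C/c2cccc([N+](=O)[O-])c2)C1` carries one change from compound 3: bromo in place of fluoro on an aromatic carbon, turning 4-fluorophenyl into 4-bromophenyl.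

Going by the values given here, no measured step replaces one halogen with another, so the data give no direct measure of this change. The closest evidence is the step of a 1.3-fold higher number from compound 2 to compound 3 (0.12 log units; within the scatter), where 4-fluorophenyl replaces 2-fluorophenyl and the size stays within the scatter. That small step gives only weak support for expecting little movement in this assay, and no direction is established.

The expected result is a 1.2-fold lower number from compound 3 to compound 4 (0.07 log units; within the scatter), which is not expected to exceed the scatter. For compound 4 the estimated value is 15000 nM, with an expected range of 7000 nM to 30000 nM.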

Compound 4, half-maximal inhibitory concentration: 9850 nM
The estimate for compound 4 lay 1.5-fold (0.18 log units) above the measured number; measured number inside the range.
By their numbers in this assay, from the lowest: compounds 4, 1, 2 and 3 (each within the scatter of the next).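

Bromo in place of fluoro on an aromatic carbon, para to a large group, can now be read directly in this assay (a 1.8-fold lower number from compound 3 to compound 4 (0.25 log units; within the scatter)), and this exchange of one halogen for another stays inside the scatter. The wider replacement of 2-fluorophenyl by 4-bromophenyl also stays inside the scatter (a 1.4-fold lower number from compound 2 to compound 4 (0.14 log units; within the scatter)), so on these compounds neither the halogen nor its place on this phenyl ring separates one compound from another. No independent measurement is available to explain these small steps.

From the compounds shown here alone, it remains open whether a group other than a halogen at this position, such as an amine or a carboxylic acid, would give a step beyond the scatter. Going by these compounds, it also remains open whether bromo in place of fluoro would read the same way with the dimethoxyphenyl side of compound 1.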